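A few compounds are considered here, and "the series" means these few. Any claim that something is new, unique, unknown or untested is made for them only; others in the source may bear on it.

Working notes on the series.

Going by the values given here, compound 1 `COc1ccc(S(=O)(=O)NC(=O)NC/C=C2\CCCc3cnn(Cc4ccc(Cl)cc4Cl)c32)cc1` is one of two compounds measured in an assay on isolated protein for displacement of a labelled ligand from prostaglandin E2 receptor EP3 subtype (Homo sapiens), read by scintillation counting, with a stated time of 2 h; on this read-out lower numbers stand for stronger inhibition and higher numbers for weaker inhibition. In this assay compound 1 gives 10 nM, the highest of the two numbers. Among the compounds with values here, compound 2 `O=C(NC/C=C1\CCCc2cnn(C3CCN(c4ccc(F)cc4)CC3)c21)NS(=O)(=O)c1cc(Cl)c(Cl)s1` carries a (4,5-dichlorothiophen-2-yl)sulfonyl group on the acylsulfonamide and, in this assay, compound 2 gives 1 nM, a number beyond the scatter below that of compound 1; compound 2 differs from compound 1 in more than one place, so no single step links the two.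

Compound 3 `O=C(NC/C=C1\CCCc2cnn(Cc3ccc(Cl)cc3Cl)c21)NS(=O)(=O)c1cc(Cl)c(Cl)s1` keeps the shared core and the dichlorobenzyl group of compound 1 and changes only the sulfonyl side: 4,5-dichlorothiophen-2-yl in place of 4-methoxyphenyl on a sulfonyl sulfur. Within the data shown here, no measured pair isolates this change. The number of compound 2 shows that the dichlorothiophene sulfonyl is compatible with strong binding, though the second difference in compound 2 is not separated from it.

The expectation for compound 3 is a step down, beyond the scatter, from compound 1 to compound 3 of a 3.3-fold lower number from compound 1 to compound 3 (0.52 log units; beyond the scatter). Compound 3 is therefore estimated at 3 nM, with a range from 1 nM to 10 nM.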

Compound 3, inhibition constant: 0.5 nM
For compound 3 the middle estimate is 6.0-fold (0.78 log units) above the measured one, and the stated range ends above it.
By their numbers in this assay, from the lowest: compounds 3 and 2 (each within the scatter of the next); then compound 1.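

Going by these compounds alone, with the dichlorobenzyl group and the shared core held constant, 4,5-dichlorothiophen-2-yl in place of 4-methoxyphenyl on a sulfonyl sulfur gives a 20-fold lower number from compound 1 to compound 3 (1.30 log units; beyond the scatter) in this assay, a large step and the first reading of this change on its own. Compound 2 had shown only that this sulfonyl group is compatible with strong binding, whereas the step now places a large effect on the sulfonyl side, and with that group in place compound 3 at 0.5 nM and compound 2 at 1 nM lie within the scatter of each other despite their different groups on the ring nitrogen. No supporting data bear on why this change has so large an effect.

Since the step swaps the whole aryl group at once, the compounds shown do not separate the contribution of the thiophene ring, the two chlorine atoms and the departing methoxy group. As far as these compounds go, an unsubstituted thiophen-2-yl or a 4-chlorophenyl on the same sulfonyl sulfur would divide the step into those parts, and how far it carries over to other groups in place of the dichlorobenzyl remains open.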